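A few compounds are considered here, and "the series" means these few. Any claim that something is new, unique, unknown or untested is made for them only; others in the source may bear on it.

Compound 1, `CCCCCCCCCCCCCCCCCCCCCCOC(=O)NC(CCC(=O)O)(CCC(=O)O)CCC(=O)O`, carries a long carbamate chain on a core bearing three carboxylic acids. In an ADME assay on cells (Epithelial cell, Homo sapiens) for cytotoxicity, read by MTT assay (a higher number here means that more compound is needed for the effect, a lower number that less compound is needed), compound 1 gives 360000 nM. Among the measured compounds shown here, the only other compound measured, compound 2, `CCCCCCCCCCCCCC(=O)NC(CCC(=O)O)(CCC(=O)O)CCC(=O)O`, has a shorter amide chain on the same core, and in this assay compound 2 gives 300000 nM; the two numbers lie within the usual scatter of each other, so neither can be called different from the other.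

Compound 3, `CCCCCCCCCCCCCCCCOC(=O)NC(CCC(=O)O)(CCC(=O)O)CCC(=O)O`, is made from compound 1 by a single change: hydrogen in place of hexyl on a saturated chain carbon, ten or more bonds along the chain from an oxygen next to a carbonyl group. For the measured compounds named here, no measured pair shows such a step, but the shorter-chained compound 2 gives no hint that chain length moves this read-out. The step is therefore expected to be a 1.1-fold lower number from compound 1 to compound 3 (0.04 log units; within the scatter), with no change beyond the scatter. Compound 3 is expected to give 330000 nM in this assay, within a range from 150000 nM to 700000 nM.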

Compound 3, half-maximal effective concentration: 440000 nM
For compound 3 the middle estimate is 1.3-fold (0.12 log units) below the measured one; low and high end bracket the measured number.
By their numbers in this assay, from the lowest: compounds 2, 1 and 3 (each within the scatter of the next).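

The change of hydrogen in place of hexyl gives, in this assay, a 1.2-fold higher number from compound 1 to compound 3 (0.09 log units; within the scatter), so no change can be read from this step. Among the compounds shown here, this is the first direct measure of a change at this place on the chain, and here the loss of hexyl does not separate the two compounds. No available evidence bears on this result.

As far as these compounds go, whether a longer chain, or an amine or a hydroxyl group at this same place, would also leave the number within the scatter remains open. From the compounds shown here alone, all three compounds keep the three carboxylic acids on the shared core, so the effect of replacing one with a methyl ester also remains open.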